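The compounds below may be only part of what the source reports. "The series", "measured", "known", "first", "only" and "open" are said of these compounds alone.

Among the measured compounds shown here, in a functional assay on HL-60 cells (Homo sapiens), read by colorimetric assay, with a stated time of 24 h (a higher number here means a weaker inhibitor, a lower number a stronger inhibitor), compound 2 `CC(=O)OC[C@@H](OC(C)=O)[C@H]1O[C@@H](n2cnc3c(Cl)ncnc32)[C@H](OC(C)=O)[C@@H]1OC(C)=O` gives 79300 nM, the only true number among the three compounds measured so far. Compound 1 `OC[C@@H](O)[C@H]1O[C@@H](n2cnc3c(Cl)ncnc32)[C@H](O)[C@@H]1O` reads > 100000 nM, which is a limit of the assay and not a number. Compound 3 `CC(=O)OC[C@@H](OC(C)=O)[C@H]1O[C@@H](n2cnc3c(-c4ccccc4)ncnc32)[C@H](OC(C)=O)[C@@H]1OC(C)=O` reads > 100000 nM, again a limit. Compound 4 `CC(=O)OC[C@@H](OC(C)=O)[C@H]1O[C@@H](n2cnc3c(Cl)nc(Cl)nc32)[C@H](OC(C)=O)[C@@H]1OC(C)=O` differs from compound 2 in one place: chloro in place of hydrogen on an aromatic carbon, with chloro in place of hydrogen on an aromatic carbon, between two ring nitrogen atoms. For the measured compounds named here, the only measured guide is an at least 1.2-fold higher number from compound 2 to compound 3 (0.10 log units; that floor lies within the scatter), a different change that ends at a limit, so it gives no firm size. A step within the scatter, with no clear direction, is therefore expected. The expected step is a 1.3-fold lower number from compound 2 to compound 4 (0.12 log units; within the scatter). For compound 4 the estimate is 60000 nM, with an expected range from 20000 nM to 100000 nM.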

Compound 4, half-maximal inhibitory concentration: 16100 nM
For compound 4 the middle estimate is 3.7-fold (0.57 log units) above the measured one, outside the stated range (below it).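

In this assay, a 4.9-fold lower number from compound 2 to compound 4 (0.69 log units; beyond the scatter) is the only change among these compounds that is printed as beyond the scatter. It shows that the aromatic carbon between two ring nitrogen atoms, which carries only hydrogen in compound 2, can take a chloro group with a modest gain in inhibition. Compound 3 reads as a limit, so its phenyl change gives no size to set against this one: the limit of > 100000 nM in this assay, at which 2 of the 4 values shown sit.

From the compounds shown here alone, whether an amine or a methoxy group on this same carbon would give a similar step stays open. So does whether the chloro step holds when free hydroxyl groups replace the acetyl esters.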